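The compounds below may be only part of what the source reports. "The series", "measured", "known", "first", "only" and "open" are said of these compounds alone.

The measured compounds in an ADME assay on L929 cells (Mus musculus) for antiproliferative activity, read by CCK-8 assay, with a stated time of 48 h; a higher number here means a weaker inhibitor, a lower number a stronger inhibitor:
Compound 1 `CC(C)CSc1n[nH]c(-n2[se]c3ccccc3c2=O)n1` gives 33400 nM.
Compound 2 `CC(C)Sc1n[nH]c(-n2[se]c3ccccc3c2=O)n1` gives 37100 nM.
For compound 3 `O=c1c2ccccc2[se]n1-c1nc(SCc2ccccc2)n[nH]1` the result is a limit of the assay rather than a number, > 50000 nM.
That reading is the limit of > 50000 nM in this assay, at which 1 of the 3 values shown sits.

Among the two numbers in this assay, compound 1 has the lower one, and its nearest neighbour is compound 2, with a 1.1-fold higher number from compound 1 to compound 2 (0.05 log units; within the scatter), so the two are not separable. Within the data shown here, the comparisons with compound 3, an at least 1.4-fold higher number from compound 1 to compound 3 (0.17 log units; that floor lies within the scatter) and an at least 1.3-fold higher number from compound 2 to compound 3 (0.12 log units; that floor lies within the scatter), rest on a limit and say only that compound 3 is not stronger than the other two.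

Compound 4 `CCCSc1n[nH]c(-n2[se]c3ccccc3c2=O)n1` is the next case. It differs from compound 1 in one place: hydrogen in place of methyl on a saturated chain carbon bound to two saturated chain carbons. Among the measured compounds shown here, the step that bears most directly on this change is the one from compound 1 to compound 2, which also trims the chain on the sulfur and gave a 1.1-fold higher number from compound 1 to compound 2 (0.05 log units; within the scatter). The steps to compound 3 exchange the alkyl for an aromatic group and bear on it only loosely. On this basis he expects no change beyond the scatter in this assay for compound 4. Compound 4 is estimated at 36000 nM, within a range from 20000 nM to 65000 nM. That estimate corresponds to an expected 1.1-fold higher number from compound 1 to compound 4 (0.03 log units; within the scatter).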

Compound 4, half-maximal inhibitory concentration: 31800 nM
Estimate against measurement, compound 4: 1.1-fold (0.05 log units) above; measured number inside the range.
By their numbers in this assay, from the lowest: compounds 4, 1 and 2 (each within the scatter of the next). At a limit, above all of these: compound 3.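

In this assay, the step that takes isobutyl to propyl on the sulfur, removing a methyl from a saturated chain carbon bound to two saturated chain carbons, is small, a 1.1-fold lower number from compound 1 to compound 4 (0.02 log units; within the scatter), and the step from isopropyl to propyl, a 1.2-fold lower number from compound 2 to compound 4 (0.07 log units; within the scatter), is of the same kind. With compound 4 added, the isobutyl, isopropyl and propyl compounds cannot be told apart, so neither removing this methyl nor moving from the isopropyl group to the propyl group shows a readable effect here. The comparison with the benzyl compound, an at least 1.5-fold lower number from compound 3 to compound 4 (0.19 log units; that floor lies within the scatter), rests on a limit of the assay rather than a number, and its floor gives no separation beyond the scatter; compound 3 is the compound at that limit: the limit of > 50000 nM in this assay, at which 1 of the 4 values shown sits.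

The compounds shown leave open whether a longer chain on the sulfur, such as hexyl or octyl, would move the number in this assay beyond the scatter. They also leave open what an amine or a carboxylic acid at the end of the chain would do.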